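The source may hold more compounds than are shown below. What is called first, only, known or untested is meant among the compounds shown, and "the series" means these compounds.

Working notes on the series.

Two compounds share the core and differ only in the saturated amine ring attached to the aromatic nitrogen. Compound 1 `CN1CCC(n2cc(S(=O)(=O)c3ccc(Cl)cc3)c3cccnc32)C1` gives 4.2 nM in an assay on HeLa cells for displacement of a labelled ligand from 5-hydroxytryptamine receptor 6 (Homo sapiens); on this read-out lower numbers stand for stronger inhibition and higher numbers for weaker inhibition. Among the measured compounds shown here, compound 2 `CN1CCCC(n2cc(S(=O)(=O)c3ccc(Cl)cc3)c3cccnc32)C1` gives 11.5 nM in this assay; on the two numbers so far compound 2 stands highest, separated from compound 1 by the step of a 2.7-fold higher number from compound 1 to compound 2 (0.44 log units; beyond the scatter), a modest change tied to the swap of 1-methylpiperidin-3-yl for 1-methylpyrrolidin-3-yl.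

Compound 3 `CCN1CCCC(n2cc(S(=O)(=O)c3ccc(Cl)cc3)c3cccnc32)C1` has not yet been measured in this assay. It differs from compound 2 by methyl in place of hydrogen on a saturated chain carbon bound to an amine nitrogen in a ring; read one bond further out, methyl becomes ethyl and 1-methylpiperidin-3-yl becomes 1-ethylpiperidin-3-yl. For the measured compounds named here, no measured step bears directly on this change: the only step in hand, from compound 1 to compound 2, alters the ring itself, and both compounds carry the same methyl on the amine nitrogen. Lacking any precedent for lengthening that substituent, the expectation for compound 3 is a step of a 1.3-fold higher number from compound 2 to compound 3 (0.12 log units; within the scatter) in this assay, likely within the scatter. Compound 3 is therefore estimated at 15 nM, with a range from 5 nM to 45 nM.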

Compound 3, inhibition constant: 33.5 nM
The estimate for compound 3 lay 2.2-fold (0.35 log units) below the measured number, and the stated range covers the measured number.
By their numbers in this assay, from the lowest: compound 1; then compound 2; then compound 3.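

The substituent on the amine nitrogen is not a neutral position in this assay in this pair: methyl to ethyl, which turns 1-methylpiperidin-3-yl into 1-ethylpiperidin-3-yl, gives a 2.9-fold higher number from compound 2 to compound 3 (0.46 log units; beyond the scatter) and so adds one carbon with a clear effect on the number. This step is of the same modest grade as the ring change, a 2.7-fold higher number from compound 1 to compound 2 (0.44 log units; beyond the scatter) and runs in the same direction, so the earlier compounds, which share the methyl group, could not have shown that this substituent matters as well. Taken as one replacement, 1-ethylpiperidin-3-yl in place of 1-methylpyrrolidin-3-yl gives an 8.0-fold higher number from compound 1 to compound 3 (0.90 log units; beyond the scatter) and that is the largest step among the three compounds; nothing in hand accounts for any of these steps.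

Open, as far as these compounds go, is whether the rise continues with a longer chain on the amine nitrogen, such as propyl or butyl, or whether a lone hydrogen there would give a lower number than methyl. Also open, from the compounds shown here alone, is whether 1-ethylpyrrolidin-3-yl would show the same step on the smaller ring, since the methyl to ethyl change is read here on the piperidine alone.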